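Swapping the amine on compound 1's aniline ring

The compounds below may be only part of what the source reports. "The series", "measured", "known", "first", "only" and "open" are said of these compounds alone.

Among the compounds with values here, compound 1, `CCCN(CCC)c1ccc(Nc2ncc(Cl)c(Oc3cccc(NC(=O)CC)c3)n2)cc1`, gives the lower of the two numbers measured so far. In an assay on isolated protein for inhibition of NUAK family SNF1-like kinase 1 (Homo sapiens), read by ADP-Glo, with a stated time of 60 min, tested at 10 uM, in the presence of a further agent that is not named here (a higher number here means more inhibition at the concentration tested (going by the name of the read-out), a lower number less inhibition), compound 1 gives 9.3%, while the other measured compound, compound 2, `CCC(=O)Nc1cccc(Oc2nc(Nc3ccc(N(C)C)cc3OC)ncc2Cl)c1`, gives 80.6%, a gap well beyond the usual scatter. The two differ in more than one place, so no single change accounts for the gap.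

Compound 3, `CCC(=O)Nc1cccc(Oc2nc(Nc3ccc(N4CCN(C)CC4)cc3)ncc2Cl)c1`, is not yet measured. It keeps the shared core of compound 1 and changes only the amine: 4-methylpiperazin-1-yl in place of dipropylamino on an aromatic carbon. Within the data shown here, no measured pair isolates this change, so no direct precedent exists. Given that compound 2, which carries a different small amine, reaches 80.6%, a rise in this assay from compound 1 to compound 3 is expected, of about a number 35.7 percentage points higher from compound 1 to compound 3 (beyond the scatter). Compound 3 is therefore estimated to give 45% in this assay, somewhere between 15% and 80%.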

Compound 3, a percentage reported as inhibition, at one concentration (the size of the read-out at that concentration, not a potency): 92.9%
The estimate for compound 3 lay 47.9 percentage points below the measured number, outside the stated range (above it).
By their numbers in this assay, from the lowest: compound 1; then compound 2; then compound 3.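

Within the data shown here, this pair is the first that differs in one place only, so the effect of the change can now be read alone: in this assay, 4-methylpiperazin-1-yl in place of dipropylamino on an aromatic carbon gives a number 83.6 percentage points higher from compound 1 to compound 3 (beyond the scatter) in a large step. Both groups hold 7 heavy atoms, so this position, para to a large group, separates two amines of equal heavy-atom count. Nothing shown here gives a reason for the rise.

From the compounds shown here alone, it remains open whether the ring or the second nitrogen goes with the rise, and a piperidin-1-yl or morpholin-4-yl group at this position would help to separate the two. Going by these compounds, the role of the methyl on the piperazine also remains open, and the unsubstituted piperazin-1-yl group would test it.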